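The compounds below may be only part of what the source reports. "The series", "measured", "known", "first", "only" and "open" are said of these compounds alone.

Measured so far in a functional assay on HBL-100 cells (Homo sapiens) for inhibition, read by sulforhodamine B assay, with a stated time of 48 h; on this read-out higher numbers stand for weaker inhibition of growth and lower numbers for stronger inhibition of growth:
compound 1 `Cc1cc(=O)oc2cc(N=C=[Se])ccc12`: 5000 nM
compound 2 `CCOC(=[Se])Nc1ccc2c(C)cc(=O)oc2c1`: a limit of the assay only, > 100000 nM
compound 3 `CCCOC(=[Se])Nc1ccc2c(C)cc(=O)oc2c1`: 34000 nM

Compound 3 holds the higher of the two numbers obtained in this assay; compound 1 holds the lower. The measured steps run as follows: an at least 20-fold higher number from compound 1 to compound 2 (1.30 log units; beyond the scatter), and an at least 2.9-fold lower number from compound 2 to compound 3 (0.46 log units; beyond the scatter). The value of compound 2 sits at the limit of > 100000 nM in this assay, at which 1 of the 3 values shown sits.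

Compound 4 `CCCCNC(=[Se])Nc1ccc2c(C)cc(=O)oc2c1` is the next member to be measured. It differs from compound 3 by butylamino in place of propoxy on a saturated chain carbon bound to a nitrogen on an aromatic ring. Among the measured compounds shown here, no measured step exchanges oxygen for nitrogen in this position, so that part of the change has no precedent. For the measured compounds named here, the only step that touches the same chain lengthened it by one carbon and lowered the number in this assay; compound 4 again carries a chain one carbon longer than compound 3. The expected step is therefore a modest lowering, a 1.7-fold lower number from compound 3 to compound 4 (0.23 log units; within the scatter), with wide uncertainty. The estimate for compound 4 in this assay is 20000 nM, within a range of 5000 nM to 80000 nM.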

Compound 4, concentration for 50% growth inhibition: 2300 nM
The estimate for compound 4 lay 8.7-fold (0.94 log units) above the measured number; the whole stated range lies above it.
By their numbers in this assay, from the lowest: compound 4; then compound 1; then compound 3. At a limit, above all of these: compound 2.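

In this assay, among the compounds shown here, the exchange of propoxy for butylamino on a saturated chain carbon bound to a nitrogen on an aromatic ring gives a 15-fold lower number from compound 3 to compound 4 (1.17 log units; beyond the scatter) and is the first sign that this position tolerates more than small shifts among the oxygen-linked chains, with butylamino also bringing a hydrogen-bond donor that propoxy lacks. The step of an at least 43-fold lower number from compound 2 to compound 4 (1.63 log units; beyond the scatter) gives only a bound on the size of the change from ethoxy to butylamino. Compound 2 stands at a limit of the assay, not at a number: the limit of > 100000 nM in this assay, at which 1 of the 4 values shown sits.

The step from propoxy to butylamino joins an oxygen-to-nitrogen exchange and a longer chain, and propylamino in the same place would separate the two. Going by these compounds, whether the hydrogen on that nitrogen matters, and how far the chain can grow, stays open for groups such as dimethylamino or hexylamino.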